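From bromo to methylamino on a shared chain

This account rests on a few compounds, and the source may have more. Where it says the series, first, only, none or still open, it means among the compounds named here.

Measured in a functional assay on MCF7 cells (Homo sapiens) for antiproliferative activity, read by MTT assay, with a stated time of 48 h; a higher number here means a weaker inhibitor, a lower number a stronger inhibitor:
- compound 1 `COc1ccc(C(=O)c2ccc3c(c2)C=CC(C)(C)O3)c(NC(=O)CBr)c1` gives 2880 nM
- compound 2 `COc1ccc(C(=O)c2ccc(OC)c3c2C=CC(C)(C)O3)c(NC(=O)CO)c1` gives 940 nM
- compound 3 `COc1ccc(C(=O)c2ccc(OC)c3c2C=CC(C)(C)O3)c(NC(=O)CN)c1` gives 1250 nM

Compound 1 (2880 nM) carries the highest number of the three, so it is the weakest inhibitor here. Its gap to compound 3 (1250 nM) lies beyond the usual scatter, and so does its gap to compound 2 (940 nM).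

Compound 4 `CNCC(=O)Nc1cc(OC)ccc1C(=O)c1ccc2c(c1)C=CC(C)(C)O2` keeps the core of compound 1 and changes one group: methylamino in place of bromo on a saturated chain carbon bound to a carbonyl carbon. In words, methylamino stands in place of bromo on a saturated chain carbon bound to a carbonyl carbon.

Among the compounds with values here, only one measured step touches this place on the chain: a 1.3-fold higher number from compound 2 to compound 3 (0.12 log units; within the scatter). That swap of hydroxy for amino stayed within the scatter. It is only a loose guide, since neither compound in it carries bromo and their core differs from that of compound 1. Within the data shown here, no measured pair shows bromo being replaced.

Only a small shift towards a lower number is therefore expected, and the estimated step is a 1.4-fold lower number from compound 1 to compound 4 (0.16 log units; within the scatter) in this assay.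

The estimate for compound 4 is 2000 nM, with an expected range from 700 nM to 6000 nM.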

Compound 4, half-maximal inhibitory concentration: 1210 nM
Beside the measured number, compound 4's estimate is 1.7-fold (0.22 log units) above it; the measured number falls inside the stated range.
By their numbers in this assay, from the lowest: compounds 2, 4 and 3 (each within the scatter of the next); then compound 1.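

In this assay the change gives a 2.4-fold lower number from compound 1 to compound 4 (0.38 log units; beyond the scatter) on the core of compound 1, the first measured replacement of bromo on this saturated chain carbon bound to a carbonyl carbon. Within the data shown here, the only earlier step at this place, a 1.3-fold higher number from compound 2 to compound 3 (0.12 log units; within the scatter) on a different core, stayed within the scatter, so the new step is the first sign that the number in this assay can move with the group on this chain carbon. Nothing shown here explains why this swap lowers the number.

With a single step on this core, the data cannot separate the loss of bromo from the arrival of methylamino, and they do not show whether hydroxy or amino on the core of compound 1 would give a similar number. Dimethylamino in the same place, or a longer chain ending in an amine, would show whether the number keeps falling as the group on this chain carbon grows or whether methylamino is a particular case.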